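The source may hold more compounds than are shown below. What is called first, only, known or untested is meant among the compounds shown, and "the series" means these compounds.

Working notes on the sulfonamide–triazole series.

Compound 1 `O=c1[nH]cc(S(=O)(=O)Nc2ccccc2-c2cn(-c3ccccc3)nn2)c(=O)[nH]1` gives 6650 nM in a functional assay on OVCAR-3 cells (Homo sapiens) for antiproliferative activity, read by MTT assay, with a stated time of 24 h; a higher number here means a weaker inhibitor, a lower number a stronger inhibitor. Going by the values given here, compound 2 `Cc1cccc(-n2cc(-c3ccccc3NS(=O)(=O)c3c[nH]c(=O)[nH]c3=O)nn2)c1` carries a methyl on the phenyl attached to the triazole and gives 3150 nM in this assay; the step of a 2.1-fold lower number from compound 1 to compound 2 (0.32 log units; beyond the scatter) is the only single-point change measured so far, and it is modest. Compound 3 `O=c1[nH]cc(S(=O)(=O)Nc2cccc(-c3cn(-c4ccccc4)nn3)c2)c(=O)[nH]1` is a ring isomer of compound 1 in the sulfonamide-bearing ring. For compound 3 this assay returns only a limit, > 20000 nM, so no number is known for it. Compound 3 therefore sits at the limit of > 20000 nM in this assay, at which 1 of the 3 values shown sits, and how far it lies from compounds 1 and 2 cannot be read from the values shown.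

Compound 4 `O=c1[nH]cc(S(=O)(=O)Nc2cccc(-c3cn(-c4ccccc4Cl)nn3)c2)c(=O)[nH]1` differs from compound 3 by chloro in place of hydrogen on an aromatic carbon. The step bearing on it is a 2.1-fold lower number from compound 1 to compound 2 (0.32 log units; beyond the scatter), a substituent placed on the same phenyl ring of the core, which moved the number a little in the lower direction. A change of similar modest size, in the same direction, is expected here; starting from a limit, a result that is again only a limit remains likely. Compound 4 is expected at 15000 nM, with a range from 6000 nM to 40000 nM. The step expected is an at least 1.3-fold lower number from compound 3 to compound 4 (0.12 log units; that floor lies within the scatter).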

Compound 4, half-maximal inhibitory concentration: 5370 nM
Compound 4: the middle estimate sits 2.8-fold (0.45 log units) above what was measured; measured number below the stated range.
By their numbers in this assay, from the lowest: compounds 2, 4 and 1 (each within the scatter of the next, the first and the last beyond it). At a limit, above all of these: compound 3.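

In this assay the change from phenyl to 2-chlorophenyl, with chloro ortho to a large group, gives an at least 3.7-fold lower number from compound 3 to compound 4 (0.57 log units; beyond the scatter), and compound 4 has a measured number (5370 nM). From the compounds shown here alone, the true size of this step remains unknown and only its floor can be read, because compound 3 stands at a limit: the limit of > 20000 nM in this assay, at which 1 of the 4 values shown sits. Going by these compounds alone, the only earlier step on this phenyl (a 2.1-fold lower number from compound 1 to compound 2 (0.32 log units; beyond the scatter)) was a methyl on the other ring isomer, so this result is the only reading of a substituent on the parent of compound 3 and the only reading of chloro.

Going by these compounds, whether the step belongs to chloro itself or to its place on the ring stays open, since an amine, a methoxy group or a carboxylic acid on the same carbon would be needed to separate the two. Also open, on these data alone, is whether chloro at this place on compound 1 would give a step of similar size, or whether the step holds only for the parent of compound 3.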